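A Trichlorophenyl Variant Near the Edge of the Assay

The compounds below may be only part of what the source reports. "The series", "measured", "known", "first", "only" and "open" are said of these compounds alone.

The measured pair consists of compound 1 `Cc1ccc(Cl)cc1-n1nncc1CN1C(=O)C2(C(C#N)=C(N)Oc3c(N)cc4nc5ccccc5nc4c32)c2ccccc21` and compound 2 `N#CC1=C(N)Oc2c(N)cc3nc4ccccc4nc3c2C12C(=O)N(Cc1cnnn1-c1ccc(F)c(Cl)c1)c1ccccc12`. In a functional assay on HCT-116 cells (Homo sapiens) for antiproliferative activity, read by MTT assay, with a stated time of 48 h (a lower number here means a stronger inhibitor, a higher number a weaker inhibitor), compound 1 gives 37200 nM. Compound 2 reaches only a limit of the assay, > 50000 nM, so no number is known for it. The single measured step, an at least 1.3-fold higher number from compound 1 to compound 2 (0.12 log units; that floor lies within the scatter), is bounded from below by the limit of > 50000 nM in this assay, at which 1 of the 2 values shown sits, and its floor lies within the scatter, so no real difference between the two aryl groups on the aromatic nitrogen has been shown.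

Compound 3 `N#CC1=C(N)Oc2c(N)cc3nc4ccccc4nc3c2C12C(=O)N(Cc1cnnn1-c1c(Cl)cc(Cl)cc1Cl)c1ccccc12` differs from compound 2 by 2,4,6-trichlorophenyl in place of 3-chloro-4-fluorophenyl on an aromatic nitrogen. For the measured compounds named here, only the step from compound 1 to compound 2 bears on this change, as it also swaps the aryl group on that same aromatic nitrogen, and it gave no resolvable step. Because compound 2 already sits at the limit of > 50000 nM in this assay, at which 1 of the 2 values shown sits, any further weakening cannot appear as a number, and only a large gain would. The expectation for compound 3 in this assay is a value near the limit, 55000 nM, with a range from 25000 nM to 120000 nM. The step that the limit leaves unreadable from compound 2 to compound 3 is expected to stay within the scatter.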

Compound 3, half-maximal inhibitory concentration: 12100 nM
Estimate against measurement, compound 3: 4.5-fold (0.66 log units) above; measured number below the stated range.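

The aryl group on the aromatic nitrogen can move the number in this assay by more than the scatter, which the pair of compound 1 and compound 2 could not show: 2,4,6-trichlorophenyl in place of 3-chloro-4-fluorophenyl gives an at least 4.1-fold lower number from compound 2 to compound 3 (0.61 log units; beyond the scatter). That size is only a floor, and the true step may be larger: the limit of > 50000 nM in this assay, at which 1 of the 3 values shown sits. The step with a number at both ends is the one against 5-chloro-2-methylphenyl, a 3.1-fold lower number from compound 1 to compound 3 (0.49 log units; beyond the scatter), so both steps to compound 3 lie beyond the scatter and it holds the lowest number of the three, although that number remains far from a strong inhibitor's.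

The compounds shown leave open whether this gain needs all three chlorines of the 2,4,6-trichlorophenyl group, or whether 2,6-dichlorophenyl or 2,4,6-trimethylphenyl on the same aromatic nitrogen would give a similar number. They also give no reason for the drop, and the order of compound 1 and compound 2 stays unresolved, so a single result with this one aryl group marks no trend across the position.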